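This account rests on a few compounds, and the source may have more. Where it says the series, first, only, none or still open, it means among the compounds named here.

Measured so far in a physicochemical assay for solubility, read by HPLC, using the shake flask method, in phosphate buffer, with a stated time of 2 h, at pH 6.5; on this read-out higher numbers stand for higher solubility and lower numbers for lower solubility
- compound 1 `Nc1ncc(-c2ccc(C(=O)N3CC(O)C3)cc2)nc1-c1ccc(C(F)(F)F)cc1` gives 55000 nM
- compound 2 `Nc1ncc(-c2ccc(C(=O)N3CCC(O)C3)cc2)nc1-c1ccc(C(F)(F)F)cc1` gives 77000 nM

Going by the values given here, only these two numbers exist in this assay so far. The gap between them is a 1.4-fold higher number from compound 1 to compound 2 (0.15 log units; within the scatter), which lies within the usual scatter of repeated measurements, so compound 1 cannot be ranked apart from compound 2.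

The next compound to be measured is compound 3 `Nc1ncc(-c2ccc(C(=O)N3CC[C@@H](O)C3)cc2)nc1-c1ccc(C(F)(F)F)cc1`. Its difference from compound 1 is 3-hydroxypyrrolidin-1-yl in place of 3-hydroxyazetidin-1-yl on a carbonyl carbon (the entering group has 1 defined stereocentre), and the rest of the structure stays the same.

Among the compounds with values here, one measured step bears on this change, because the same exchange of groups gave a 1.4-fold higher number from compound 1 to compound 2 (0.15 log units; within the scatter) and stayed within the scatter. That is a single step, and no measured number shows what the defined stereocentre means here. The expectation in this assay is therefore no step beyond the scatter, in either direction. In numbers, the estimated step is a 1.3-fold higher number from compound 1 to compound 3 (0.10 log units; within the scatter) and remains within the scatter. For compound 3 the estimate is 70000 nM, with an expected range from 35000 nM to 140000 nM.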

Compound 3, solubility: 90000 nM
Compound 3: middle estimate off by 1.3-fold (0.11 log units), on the low side; the range from low to high includes it.
By their numbers in this assay, from the lowest: compounds 1, 2 and 3 (each within the scatter of the next).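

In this assay, putting 3-hydroxypyrrolidin-1-yl in place of 3-hydroxyazetidin-1-yl on the carbonyl carbon, this time with a defined stereocentre, gives a 1.6-fold higher number from compound 1 to compound 3 (0.21 log units; within the scatter), so a second example of this exchange also fails to separate the compounds. Going by these compounds alone, the new compound also allows the first look at the stereocentre itself, and drawing it as R brings no separation either, with a 1.2-fold higher number from compound 2 to compound 3 (0.07 log units; within the scatter). This second comparison can only go so far, because all it rests on is a difference in how the two structures are drawn: the fact that one of compounds 2 and 3 is drawn with a defined configuration and the other without, at the place where they differ

The compounds shown leave open whether the S form of 3-hydroxypyrrolidin-1-yl would read differently from compound 3, and whether any group on this carbonyl carbon can move the number beyond the scatter. All three compounds carry a hydroxy-bearing ring there, so a different kind of group, such as an open-chain amine or one bearing a carboxylic acid, would be a far wider test of this position than another exchange of ring size.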